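A few compounds are considered here, and "the series" means these few. Any claim that something is new, unique, unknown or untested is made for them only; others in the source may bear on it.

Measured so far:
Compound 2 `CCC(C(=O)N[C@@H](CC(=O)O)C(=O)CSCc1ccccc1)n1ccnc(NCc2nc(C)no2)c1=O` — 6420 nM
Compound 3 `CCC(C(=O)N[C@@H](CC(=O)O)C(=O)CNCN1CCC(Cc2ccccc2)CC1)n1ccnc(NCc2nonc2C)c1=O` — 6020 nM
Compound 1 `CCC(C(=O)N[C@@H](CC(=O)O)C(=O)CNCN1CCCCC1)n1cc(C(C)(C)C)nc(NCc2nonc2C)c1=O` — a limit, see below

In an assay for inhibition of Caspase-8 (Homo sapiens) (a lower number here means a stronger inhibitor, a higher number a weaker inhibitor), compound 2 gives 6420 nM. Compound 3 gives 6020 nM, and the gap between compound 2 and compound 3 lies within the scatter, so the two are not separated. Compound 2 thus holds the higher of the two numbers, but only nominally. For compound 1 the result is a limit only: in this assay compound 1 gives > 10000 nM, a limit of the assay and not a number, and it sits at the limit of > 10000 nM in this assay, at which 1 of the 3 values shown sits. For the measured compounds named here, no pair of measured compounds differs in a single place, so no step has been measured.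

Compound 4 `CCC(C(=O)N[C@@H](CC(=O)O)C(=O)CSCc1ccccc1)n1ccnc(NCc2cncs2)c1=O` has not yet been measured. It differs from compound 2 as follows: 1,3-thiazol-5-yl in place of 3-methyl-1,2,4-oxadiazol-5-yl on a saturated chain carbon bound to a nitrogen on an aromatic ring. Going by the values given here, nothing among the measured compounds shows what a change of this kind does in this assay, so the expectation rests on compound 2 alone and on the small size of the change. The estimate is therefore for no step beyond the scatter. Compound 4 is expected to give 6000 nM, with a range from 2500 nM to 15000 nM. That estimate amounts to a 1.1-fold lower number from compound 2 to compound 4 (0.03 log units; within the scatter), which is within the scatter.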

Compound 4, half-maximal inhibitory concentration: 6590 nM
Compound 4: middle estimate off by 1.1-fold (0.04 log units), on the low side; measured number inside the range.
By their numbers in this assay, from the lowest: compounds 3, 2 and 4 (each within the scatter of the next). At a limit, above all of these: compound 1.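

In this assay, for the compounds shown here, this is the first step read: 1,3-thiazol-5-yl in place of 3-methyl-1,2,4-oxadiazol-5-yl, on a saturated chain carbon bound to a nitrogen on an aromatic ring, gives a 1.0-fold higher number from compound 2 to compound 4 (0.01 log units; within the scatter) and so does not separate the two compounds. At this position, then, one five-membered aromatic ring can replace the other, with sulfur entering and oxygen leaving, without a readable change in the number. Nothing measured here bears on why the exchange makes no difference.

As far as these compounds go, it remains open whether an amine, a carboxylic acid or a longer chain at this place would move the number beyond the scatter. From the compounds shown here alone, it is also open whether the same exchange would read the same way in a compound built like compound 3.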